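One Aryl Swap, Little Change Expected

The source may report more compounds than this note shows. Statements on the series, on what has been measured and on what is new or still open speak of the compounds shown alone.

Among the compounds with values here, in a functional assay on Caco-2 cells (Homo sapiens), read by fluorescence and BrdU incorporation, with a stated time of 48 h, tested at 10 uM (on this read-out higher numbers stand for a weaker effect at the one concentration tested and lower numbers for a stronger effect), compound 2 `COc1cccc(/C=C/C(=O)c2c(OC)cc(OC)cc2OC)c1` gives 31%, the lowest of the three numbers measured so far. Compound 1 `COc1cc(OC)c(C(=O)/C=C/c2ccccc2SC)c(OC)c1` gives 36%, which lies within the scatter of compound 2, while compound 3 `COc1cc(O)c(C(=O)/C=C/c2ccccc2OC)c(OC)c1` gives 46%, a number beyond the scatter above compound 2. Compound 4 `COc1cc(OC)c(C(=O)/C=C/c2ccc(Br)cc2)c(OC)c1` differs from compound 2 by 4-bromophenyl in place of 3-methoxyphenyl on a double-bonded chain carbon bound to a double-bonded chain carbon. Within the data shown here, one measured step bears on this change, because it swaps the aryl group at the same place: a number 5 percentage points lower from compound 1 to compound 2 (within the scatter). That swap left the read-out essentially unchanged, so for this assay no step beyond the scatter is expected in either direction. The step is therefore estimated as a number 2 percentage points higher from compound 2 to compound 4 (within the scatter). Compound 4 is expected to give 33%, within a range from 20% to 48%.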

Compound 4, a percentage reported as activity, at one concentration (the size of the read-out at that concentration, not a potency): 36%
Beside the measured number, compound 4's estimate is 3 percentage points below it; low and high end bracket the measured number.
By their numbers in this assay, from the lowest: compounds 2, 1, 4 and 3 (each within the scatter of the next, the first and the last beyond it).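

In this assay 4-bromophenyl on a double-bonded chain carbon brings a number 5 percentage points higher from compound 2 to compound 4 (within the scatter) and no change at the digits printed from compound 1 to compound 4 (within the scatter) on the shared core. So a bromine-bearing ring without hydrogen-bond acceptors now joins 3-methoxyphenyl and 2-(methylsulfanyl)phenyl, and all three aryl groups stay within the scatter of each other at this place. Nothing measured here explains this closeness. From the compounds shown here alone, whether a phenyl ring carrying an amine or a carboxylic acid would move the number beyond the scatter remains open. The same holds for a longer chain in place of the ring.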